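Replacing 4-fluorophenyl with 2,6-difluorophenyl on a saturated ring carbon

A few compounds are considered here, and "the series" means these few. Any claim that something is new, unique, unknown or untested is made for them only; others in the source may bear on it.

Compound 1 (`COc1ccc(C2=NO[C@]3(C2)C(=O)O[C@@H]2[C@H]3CC[C@H](C)[C@]3(O)C=CC(=O)[C@@]23C)cc1`): 1.47
Compound 2 (`C[C@H]1CC[C@@H]2[C@@H](OC(=O)[C@]23CC(c2ccc(F)cc2)N(c2ccccc2)O3)[C@]2(C)C(=O)C=C[C@@]12O`): 3.35

Among the compounds with values here, both values come from a physicochemical assay for lipophilicity (on this read-out lower numbers stand for lower lipophilicity and higher numbers for higher lipophilicity), and are the only measurements so far. Compound 2 at 3.35 stands highest of the two, and compound 1 at 1.47 lies lower by more than the usual scatter. Within the data shown here, no pair of measured compounds differs in only one place, so no measured step bears directly on the next change.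

Compound 3 (`C[C@H]1CC[C@@H]2[C@@H](OC(=O)[C@]23CC(c2c(F)cccc2F)N(c2ccccc2)O3)[C@]2(C)C(=O)C=C[C@@]12O`) has not yet been measured. It differs from compound 2 in one place (2,6-difluorophenyl in place of 4-fluorophenyl on a saturated ring carbon), with 2,6-difluorophenyl in place of 4-fluorophenyl on a saturated ring carbon, next to the ring nitrogen. Among the measured compounds shown here, the estimate therefore starts from compound 2 at 3.35 and has no measured step to guide it. In this assay a small upward step, within the usual scatter, is expected (a number 0.10 log units higher from compound 2 to compound 3 (within the scatter)). For compound 3 the expected value is 3.45, with an estimated range of 3.05 to 3.85 once it is measured.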

Compound 3, partition coefficient: 3.42
For compound 3 the middle estimate is 0.03 log units above the measured one; measured number inside the range.
By their numbers in this assay, from the lowest: compound 1; then compounds 2 and 3 (each within the scatter of the next).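

In this assay, putting 2,6-difluorophenyl in place of 4-fluorophenyl on a saturated ring carbon, next to the ring nitrogen, gives a number 0.07 log units higher from compound 2 to compound 3 (within the scatter). Within the data shown here, this is the first change that can be read in one place, and it shows that at this carbon, the two fluorinated phenyl groups cannot be told apart on this read-out, even though the entering group holds 2 fluorine where the leaving group holds 1. The measurements at hand offer nothing that explains this result.

As far as these compounds go, this is a single step between two closely related aromatic groups, so it sets no rule for this carbon, and whether an amine, a carboxylic acid or a longer alkyl chain in place of the fluorinated phenyl ring would also stay within the scatter remains open. Also open, from the compounds shown here alone, is how this assay would respond to a change on the ring atom that bears a phenyl group, for instance a pyridine ring there, and whether the outcome at the saturated ring carbon would hold alongside such a change.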